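Removing the Aromatic Ester from the Lactone Core

The compounds below may be only part of what the source reports. "The series", "measured", "known", "first", "only" and "open" are said of these compounds alone.

Of the compounds shown here, three sharing one core have been measured in a functional assay on MCF7 cells (Homo sapiens) for antiproliferative activity, read by MTT assay, with a stated time of 6 days; a lower number here means a stronger inhibitor, a higher number a weaker inhibitor. Compound 1 `CC(=O)O[C@@H]1C=CC(=O)O[C@@H]1[C@@H](COC(=O)c1ccc(Cl)cc1)OC(C)=O` gives 2640 nM. Compound 2 `COc1ccc(/C=C/C(=O)OC[C@@H](OCc2ccccc2)[C@H]2OC(=O)C=C[C@H]2OCc2ccccc2)cc1` gives 1110 nM. Compound 3 `O=C1C=C[C@@H](OCc2ccccc2)[C@@H]([C@@H](COC(=O)/C=C/c2ccc([N+](=O)[O-])cc2)OCc2ccccc2)O1` gives 1660 nM. Compound 2 has the lowest of the three numbers: its nearest neighbour is compound 3, reached by a 1.5-fold higher number from compound 2 to compound 3 (0.17 log units; within the scatter), a step within the scatter, while compound 1 stands furthest from it, beyond the scatter. The step to compound 4 `O=C1C=C[C@@H](OCc2ccccc2)[C@@H]([C@@H](CO)OCc2ccccc2)O1` is a different kind of change: hydrogen in place of (2-(4-methoxyphenyl)ethenyl)carbonyl on an oxygen on a saturated carbon. Going by the values given here, the only measured step, from compound 2 to compound 3, swaps one substituent on the aromatic ring and keeps the ester intact, so it does not bear directly on this change. Every measured compound carries an ester at this oxygen, and here the whole aromatic portion leaves; a step toward a higher number seems likely, of moderate size. Compound 4 is therefore expected to give about 5000 nM, with a range from 1500 nM to 16000 nM. The expected step is a 4.5-fold higher number from compound 2 to compound 4 (0.65 log units; beyond the scatter).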

Compound 4, half-maximal inhibitory concentration: 17600 nM
For compound 4 the middle estimate is 3.5-fold (0.55 log units) below the measured one; the whole stated range lies below it.
By their numbers in this assay, from the lowest: compounds 2, 3 and 1 (each within the scatter of the next, the first and the last beyond it); then compound 4.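

Replacing the whole (2-(4-methoxyphenyl)ethenyl)carbonyl on this oxygen with hydrogen gives a 16-fold higher number from compound 2 to compound 4 (1.20 log units; beyond the scatter) in this assay, leaving a free alcohol on the chain. The earlier step between compound 2 and compound 3 changed only a substituent on the aromatic ring and stayed within the scatter, whereas this change shows that removing the entire group can move the number well beyond it. No supporting measurement bears on the reason for this rise.

Compound 4 loses the aromatic ring, the double bond and the ester link all at once, so the compounds shown cannot separate the contribution of each part. They also leave open how a methyl ether, a longer saturated acyl chain or an amine at this place would compare with the free alcohol.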